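Removing the Nitro Group from Compound 1

The source may report more compounds than this note shows. Statements on the series, on what has been measured and on what is new or still open speak of the compounds shown alone.

In a functional assay on A549 cells (Homo sapiens) for antiproliferative activity, read by CCK-8 assay, with a stated time of 72 h (a lower number here means a stronger inhibitor, a higher number a weaker inhibitor), compound 1 `Nc1ccccc1NC(=O)c1ccc(COc2ccc([N+](=O)[O-])cc2)cc1` gives > 32000 nM, which is a limit of the assay and not a number. Compound 1 therefore stands at the limit of > 32000 nM in this assay, at which 1 of the 3 values shown sits. Compound 2 `Nc1ccccc1NC(=O)c1ccc(COc2ccc(Br)cc2)cc1` gives a measured 24400 nM. For compound 3 `Nc1ccccc1NC(=O)c1ccc(CN2CCc3cc(Br)ccc32)cc1`, the entry reads "not determined" (no result reported), so it offers no guidance.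

The next compound, compound 4 `Nc1ccccc1NC(=O)c1ccc(COc2ccccc2)cc1`, carries hydrogen in place of nitro on an aromatic carbon, turning 4-nitrophenyl into phenyl: hydrogen in place of nitro on an aromatic carbon. Within the data shown here, only one measured step bears on this change, since it replaces the same nitro group with bromo: an at least 1.3-fold lower number from compound 1 to compound 2 (0.11 log units; that floor lies within the scatter). That step rests on a limit and does not clear the scatter, so it gives only a weak hint of direction. With compound 2 at 24400 nM as the nearest real number, a small shift towards a lower number is expected in this assay, and weak activity should persist. The expected change is an at least 1.6-fold lower number from compound 1 to compound 4 (0.20 log units; that floor lies within the scatter). For compound 4 the estimated value is 20000 nM, with an expected range of 9000 nM to 32000 nM.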

Compound 4, half-maximal inhibitory concentration: 6760 nM
For compound 4 the middle estimate is 3.0-fold (0.47 log units) above the measured one; measured number outside the range, below it.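

In this assay, the change from 4-nitrophenyl to phenyl gives a step that can be read clearly, an at least 4.7-fold lower number from compound 1 to compound 4 (0.67 log units; beyond the scatter), whereas the earlier bromo step only had a floor within the scatter. Compound 1, where this step starts, stands at a limit of the assay and not a number: the limit of > 32000 nM in this assay, at which 1 of the 4 values shown sits. The step between two real numbers, a 3.6-fold lower number from compound 2 to compound 4 (0.56 log units; beyond the scatter), shows that bare phenyl also gives a lower number than the bromo compound, so at this position, on an aromatic carbon para to a large group, hydrogen serves better than either nitro or bromo.

The compounds shown carry only these three groups here, so it stays open whether fluoro, methoxy or an amine would fall below compound 4. On these data alone, it also stays open whether the same order holds at other places on this ring.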